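Replacing the pyrrolidin-1-yl group of compound 2

The compounds below may be only part of what the source reports. "The series", "measured", "known", "first", "only" and "open" are said of these compounds alone.

In an ADME assay on microsomes from liver (Rattus norvegicus) for metabolic stability (on this read-out lower numbers stand for slow clearance and higher numbers for fast clearance), compound 1 `CCCC(C#N)(CCC)Nc1nc(NC)nc(-n2cncn2)n1` gives 32 mL/min/kg and compound 3 `C#CC(CC)(CC)Nc1nc(NC)nc(-n2cncn2)n1` gives 22 mL/min/kg as measured numbers. Compound 2 `CNc1nc(NC2(C#N)CCCCC2)nc(N2CCCC2)n1` is reported as > 276 mL/min/kg in the same test, and this is a limit of the assay and not a number. Compound 4 `CNc1nc(NC2(C#N)CCCCC2)nc(-n2cnc(C#N)n2)n1` keeps the rest of compound 2 and changes one place: 3-cyano-1H-1,2,4-triazol-1-yl stands in place of pyrrolidin-1-yl on an aromatic carbon 3-cyano-1H-1,2,4-triazol-1-yl in place of pyrrolidin-1-yl on an aromatic carbon of the shared core. For the measured compounds named here, no measured pair shows this change alone, so its size can only be judged indirectly. Compound 1 and compound 3 also hold a five-membered aromatic ring with 3 hetero atoms at that place, though they differ from compound 4 elsewhere too. On that basis a large fall in this assay is expected, and the expected step of an at least 6.1-fold lower number from compound 2 to compound 4 (0.78 log units; beyond the scatter) is well beyond the usual scatter. For compound 4 the estimated clearance is 45 mL/min/kg (15 mL/min/kg to 130 mL/min/kg).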

Compound 4, clearance: 210 mL/min/kg
The estimate for compound 4 lay 4.7-fold (0.67 log units) below the measured number; the measured number lies above the stated range.
By their numbers in this assay, from the lowest: compounds 3 and 1 (each within the scatter of the next); then compound 4. At a limit, above all of these: compound 2.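

In this assay, compound 2 stands at > 276 mL/min/kg, which is a limit of the assay and not a number. For the compounds shown here, compound 4 gives a measured number, so 3-cyano-1H-1,2,4-triazol-1-yl at this position provides the first value on this scaffold that later changes can be compared with, and the change amounts to an at least 1.3-fold lower number from compound 2 to compound 4 (0.11 log units; that floor lies within the scatter). That floor does not tell whether the true fall is small or large, because the starting point is only a bound: the limit of > 276 mL/min/kg in this assay, at which 1 of the 4 values shown sits.

Going by these compounds, it remains open how much the nitrile on the ring contributes, which the plain 1H-1,2,4-triazol-1-yl group on the rest of compound 4 would help to separate. On these data alone, it also remains open how an open-chain amine such as dimethylamino, or a morpholin-4-yl group, would read at this place.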